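The source may hold more compounds than are shown below. What is called first, only, known or untested is meant among the compounds shown, and "the series" means these compounds.

Working notes. Compound 1 `C[C@H](NC(=O)c1c(NCc2ccc(C(F)(F)F)cc2)sc2c1CCOC2)c1ccc(C(=O)O)cc1` and compound 2 `COc1ccc(Cc2sc3c(c2C(=O)N[C@@H](C)c2ccc(C(=O)O)cc2)CCOC3)cc1` share one core and differ in the side group carried on it. In a functional assay on CHO/Galpha16 cells for antagonist activity at prostaglandin E2 receptor EP1 subtype (Homo sapiens), read by calcium flux, with a stated time of 15 min (on this read-out higher numbers stand for weaker inhibition and lower numbers for stronger inhibition), compound 1 gives > 10000 nM, which is a limit of the assay and not a number. In this assay compound 2 gives > 10000 nM, again a limit rather than a number. Among the measured compounds shown here, compound 2 therefore stands at the limit of > 10000 nM in this assay, at which 2 of the 2 values shown sit; no measured step between the two compounds can be drawn from this.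

Compound 3 `COc1ccc(Cc2sc3c(c2C(=O)N[C@@H](C)c2ccc(C(=O)O)cc2)CCOC3)cc1F` follows from compound 2 by fluoro in place of hydrogen on an aromatic carbon. For the measured compounds named here, with both values shown sitting at the limit, there is no measured pair to set the size of such a change, so no step beyond the usual scatter is expected, and the step from compound 2 to compound 3 is estimated as a step that the limit leaves unreadable from compound 2 to compound 3. Compound 3 is accordingly expected to give about 15000 nM in this assay, within a range of 3000 nM to 60000 nM, most likely reported as a limit only.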

Compound 3, half-maximal inhibitory concentration: > 10000 nM
Compound 3: a limit, no number (the forecaster's own chance of this, stated with the estimate: 80%); the middle value lies beyond the limit too.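

Compound 3 gives > 10000 nM in this assay, a limit and not a number. No step can be read from compound 2 to compound 3, since all the values stand at one limit: the limit of > 10000 nM in this assay, at which 3 of the 3 values shown sit. The compounds shown leave open what size the fluoro change has and whether any side group on the shared core gives a readable number.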